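Removing a bromo from compound 3

The source may report more compounds than this note shows. Statements on the series, on what has been measured and on what is new or still open speak of the compounds shown alone.

Of the compounds shown here, three on a shared core have numbers so far in a functional assay on MCF7 cells (Homo sapiens) for antiproliferative activity, read by MTT assay, with a stated time of 48 h; a higher number here means a weaker inhibitor, a lower number a stronger inhibitor. Compound 1 `Cc1ccc(C(=O)/C=C/c2cc(Br)cc(Br)c2Oc2c([N+](=O)[O-])cc(C(F)(F)F)cc2[N+](=O)[O-])cc1` gives 1.44 ug/mL, compound 2 `Cc1ccc(C(=O)/C=C/c2cccc(Br)c2Oc2c([N+](=O)[O-])cc(C(F)(F)F)cc2[N+](=O)[O-])cc1` gives 0.55 ug/mL, and compound 3 `COc1ccc(C(=O)/C=C/c2cc(Br)cc(Br)c2Oc2c([N+](=O)[O-])cc(C(F)(F)F)cc2[N+](=O)[O-])cc1` gives 3.53 ug/mL. Compound 3 therefore holds the highest number of the three and is the weakest inhibitor in this small set, with its gaps to both others beyond the scatter.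

Compound 4 `COc1ccc(C(=O)/C=C/c2cccc(Br)c2Oc2c([N+](=O)[O-])cc(C(F)(F)F)cc2[N+](=O)[O-])cc1` has not been measured. It departs from compound 3 by hydrogen in place of bromo on an aromatic carbon, which is hydrogen in place of bromo on an aromatic carbon.

The same exchange has been measured once, among the compounds carrying methyl where compound 3 and compound 4 carry methoxy, and it gives a 2.6-fold lower number from compound 1 to compound 2 (0.42 log units; beyond the scatter). The other measured step, methoxy in place of methyl, gives a 2.5-fold higher number from compound 1 to compound 3 (0.39 log units; beyond the scatter). Applied to compound 2 at 0.55 ug/mL, that step points to the same region as the first step applied to compound 3. As far as these compounds go, both steps are modest, and each rests on a single pair, so carry-over between the two sets remains untested.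

A modest step towards a lower number is expected, with the estimated change being a 2.6-fold lower number from compound 3 to compound 4 (0.42 log units; beyond the scatter). Compound 4 is estimated at 1.35 ug/mL, with an expected range of 0.6 ug/mL to 3 ug/mL.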

Compound 4, half-maximal inhibitory concentration: 2.32 ug/mL
Beside the measured number, compound 4's estimate is 1.7-fold (0.24 log units) below it, and the stated range covers the measured number.
By their numbers in this assay, from the lowest: compound 2; then compounds 1, 4 and 3 (each within the scatter of the next, the first and the last beyond it).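

In this assay, hydrogen in place of the bromo at this position, meta to a 2-((4-methoxyphenyl)carbonyl)ethenyl group, gives a 1.5-fold lower number from compound 3 to compound 4 (0.18 log units; within the scatter), so on the methoxy compounds the exchange does not clear the scatter, as it did on the methyl compounds. The two readings of this exchange still cannot be told apart: the same change on two cores in this assay, a 2.6-fold lower number (0.42 log units; beyond the scatter) from compound 1 to compound 2 and a 1.5-fold lower number (0.18 log units; within the scatter) from compound 3 to compound 4, 1.7-fold (0.24 log units) apart, within the scatter of two such steps

The second reading of methoxy in place of methyl, a 4.2-fold higher number from compound 2 to compound 4 (0.63 log units; beyond the scatter), stays beyond the scatter on the compounds lacking this bromo, and it agrees with the first: the same change on two cores in this assay, a 2.5-fold higher number (0.39 log units; beyond the scatter) from compound 1 to compound 3 and a 4.2-fold higher number (0.63 log units; beyond the scatter) from compound 2 to compound 4, 1.7-fold (0.24 log units) apart, within the scatter of two such steps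

The compounds shown compare only bromo and hydrogen at this position, so the numbers for a chloro, a nitrile or an amine there remain open. Methyl and methoxy are likewise the only pair at the other varied place, leaving open whether a hydroxy or a dimethylamino group would follow the same exchange on either core.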